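The source may report more compounds than this note shows. Statements on the series, on what has been measured and on what is new or still open speak of the compounds shown alone.

Working notes on the series.

The shared core is varied at two places: the saturated chain carbon bound to an aromatic carbon, and the aromatic ring of the anilide. Compound 1 `CCCCCCCc1nc(N)n(CC(=O)Nc2ccccc2)c1-c1ccccc1Br` carries the hexyl chain there; in a functional assay on A-375 cells (Homo sapiens) for antiproliferative activity, read by MTT assay, with a stated time of 48 h (a higher number here means a weaker inhibitor, a lower number a stronger inhibitor), compound 1 gives 9200 nM. Compound 2 `Nc1nc(CC2CCCC2)c(-c2ccccc2Br)n1CC(=O)Nc1ccccc1` has cyclopentyl in its place, and in this assay compound 2 gives 24300 nM; the step is a 2.6-fold higher number from compound 1 to compound 2 (0.42 log units; beyond the scatter). Compound 3 `Cc1ccc(NC(=O)Cn2c(N)nc(CC3CCCC3)c2-c2ccccc2Br)cc1` adds a methyl on an aromatic carbon of the anilide, and in this assay compound 3 gives 47800 nM; the step is a 2.0-fold higher number from compound 2 to compound 3 (0.29 log units; within the scatter). Compound 3 thus has the highest number of the three, but is within the scatter of compound 2 and beyond it only against compound 1.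

Compound 4 `Cc1ccc(NC(=O)Cn2c(N)nc(Cc3ccc(C(C)(C)C)cc3)c2-c2ccccc2Br)cc1` is the next variant: 4-(tert-butyl)phenyl in place of cyclopentyl on a saturated chain carbon bound to an aromatic carbon. Going by the values given here, only the step from compound 1 to compound 2 touches the same place, and it was modest, a 2.6-fold higher number from compound 1 to compound 2 (0.42 log units; beyond the scatter); no measured step exchanges a saturated ring for an aromatic one here. A step of similar modest size in either direction is therefore expected, and the estimate for compound 4 is a 1.6-fold lower number from compound 3 to compound 4 (0.20 log units; within the scatter). In this assay compound 4 is expected near 30000 nM, within 8000 nM to 110000 nM.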

Compound 4, half-maximal inhibitory concentration: 1400 nM
Compound 4: middle estimate off by 21-fold (1.33 log units), on the high side, and the stated range ends above it.
By their numbers in this assay, from the lowest: compound 4; then compound 1; then compounds 2 and 3 (each within the scatter of the next).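

In this assay the exchange of cyclopentyl for 4-(tert-butyl)phenyl on a saturated chain carbon bound to an aromatic carbon gives a 34-fold lower number from compound 3 to compound 4 (1.53 log units; beyond the scatter) and so shows that this position can move the read-out much further than the earlier change there (a 2.6-fold higher number from compound 1 to compound 2 (0.42 log units; beyond the scatter)) had indicated. It also shows that a lower number can be reached at this position, with the direction opposite to that of the step from hexyl to cyclopentyl, while the anilide methyl of compound 3 is kept. The change replaces a five-membered non-aromatic ring of 5 heavy atoms with a six-membered aromatic ring in a group of 10 heavy atoms, neither group carrying a hydrogen-bond donor or acceptor, and nothing available explains the size of the step.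

The compounds shown cannot separate the contribution of the aromatic ring from that of the tert-butyl group, and a plain phenyl, a 4-methylphenyl or a 4-(carboxylic acid)phenyl at this position would be needed to divide the step. Going by these compounds, it also remains open whether the 4-(tert-butyl)phenyl group gives a step of similar size on the unsubstituted anilide, or whether an amine on the ring changes the picture.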